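Replacing methyl with hydroxy on the phenyl ring

The source may report more compounds than this note shows. Statements on the series, on what has been measured and on what is new or still open speak of the compounds shown alone.

Measured in a functional assay on A549 cells (Homo sapiens) for antiproliferative activity, read by MTT assay, with a stated time of 72 h; on this read-out lower numbers stand for stronger inhibition and higher numbers for weaker inhibition:
- compound 1 `COc1cc(-n2cnc3ccc(-c4ccccc4Cl)cc32)cc(OC)c1OC`: > 10000 nM, a limit and not an exact number
- compound 2 `COc1cc(-n2cnc3ccc(-c4cccc(N)c4)cc32)cc(OC)c1OC`: 640 nM
- compound 3 `COc1cc(-n2cnc3ccc(-c4ccc(C)cc4)cc32)cc(OC)c1OC`: 1940 nM

Compound 3 has the higher of the two exact numbers, and compound 1 is known only by its limit. The closest comparison is a 3.0-fold higher number from compound 2 to compound 3 (0.48 log units; beyond the scatter).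

Compound 4 `COc1cc(-n2cnc3ccc(-c4ccc(O)cc4)cc32)cc(OC)c1OC` has hydroxy in place of methyl on an aromatic carbon, para to a large group: hydroxy in place of methyl on an aromatic carbon.

Among the compounds with values here, no measured step makes this exact exchange, so the evidence is indirect. The step from 3-aminophenyl to 4-methylphenyl bears most closely: a 3.0-fold higher number from compound 2 to compound 3 (0.48 log units; beyond the scatter). The steps away from 2-chlorophenyl, an at least 15-fold lower number from compound 1 to compound 2 (1.19 log units; beyond the scatter) and an at least 5.1-fold lower number from compound 1 to compound 3 (0.71 log units; beyond the scatter), show that this part of the molecule can change the number strongly, but both start from a limit.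

A modest move towards a lower number is therefore expected in this assay, landing nearer compound 2, which gives 640 nM. The expected change is a 2.3-fold lower number from compound 3 to compound 4 (0.36 log units; beyond the scatter).

For compound 4 the estimated value is 850 nM, with an expected range from 250 nM to 3000 nM.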

Compound 4, half-maximal inhibitory concentration: 5090 nM
Beside the measured number, compound 4's estimate is 6.0-fold (0.78 log units) below it; measured number above the stated range.
By their numbers in this assay, from the lowest: compound 2; then compound 3; then compound 4. At a limit, above all of these: compound 1.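

Within the data shown here, exchanging a single atom at this place gives the first direct reading of the position: a 2.6-fold higher number from compound 3 to compound 4 (0.42 log units; beyond the scatter), so the hydrogen-bond donor that enters with hydroxy does not lower the number here. Exchanging the aryl group shows a wider gap, an 8.0-fold higher number from compound 2 to compound 4 (0.90 log units; beyond the scatter), which puts the 4-hydroxyphenyl group well behind the 3-aminophenyl group of compound 2. Only a floor can be read for the remaining comparison, an at least 1.9-fold lower number from compound 1 to compound 4 (0.29 log units; that floor lies within the scatter), and it rests on a limit rather than a number: the limit of > 10000 nM in this assay, at which 1 of the 4 values shown sits.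

Compound 2 and compound 4 differ both in the group and in where it sits on the ring, so the compounds shown cannot separate these two changes. Also open, on these data alone, is how an amine or a carboxylic acid would compare in the place of the hydroxy, para to a large group.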